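A Single Fluoro Swap on Compound 1

This account rests on a few compounds, and the source may have more. Where it says the series, first, only, none or still open, it means among the compounds named here.

Measured in a physicochemical assay for lipophilicity, read by HPLC, measured as chromatographic lipophilicity, at pH 7.4; on this read-out lower numbers stand for lower lipophilicity and higher numbers for higher lipophilicity:
- compound 1 `Cc1ccc(C2CC=NN2C(=O)C(C)(C)C)cc1`: 6.4
- compound 2 `Cc1nnc(N2CCC(C(=O)N3N=CC[C@H]3c3ccccc3)CC2)o1`: 3.2

Compound 1 holds the higher of these two numbers, and compound 2 lies well below it, a gap far beyond the usual scatter of repeated measurements. The next compound to be measured is compound 3 `Cc1ccc(C2CC=NN2C(=O)C(C)(C)C)cc1F`, which differs from compound 1 in one place: fluoro in place of hydrogen on an aromatic carbon. Here fluoro takes the place of hydrogen on an aromatic carbon, ortho to a methyl group and meta to a large group. Among the compounds with values here, no measured pair shows this change, so the expectation rests on judgement alone. A small upward step in this assay is expected, one that stays within the usual scatter. The expected step is a number 0.20 log units higher from compound 1 to compound 3 (within the scatter). For compound 3 the estimated value is 6.6, with an expected range from 6.2 to 7.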

Compound 3, distribution coefficient: 6.6
Estimate against measurement, compound 3: no gap at the digits printed, and the stated range covers the measured number.
By their numbers in this assay, from the lowest: compound 2; then compounds 1 and 3 (each within the scatter of the next).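

In this assay, within the data shown here, fluoro in place of hydrogen on an aromatic carbon, ortho to a methyl group and meta to a large group, gives a number 0.20 log units higher from compound 1 to compound 3 (within the scatter) and offers the first comparison here of two compounds that differ in one place. On this read-out, compound 1 and compound 3 cannot be told apart, so at this position the swap produces no change that stands clear of ordinary measurement noise. Nothing available here offers an explanation for the size of this step.

From the compounds shown here alone, it remains open whether a methoxy group, a chlorine atom or an amine at this same carbon would shift the number beyond the scatter. It is also unknown whether fluoro would behave the same way at another carbon of this ring or on the core of compound 2.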